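3-Methylbenzyl to 3-(trifluoromethyl)benzyl: working notes

The source may hold more compounds than are shown below. What is called first, only, known or untested is meant among the compounds shown, and "the series" means these compounds.

In a functional assay on THP-1 cells (Homo sapiens) for inhibition (a lower number here means a stronger inhibitor of growth, a higher number a weaker inhibitor of growth), compound 1 `Cc1noc(C)c1-c1ccc2c(c1)c(Cc1ccccc1)cn2CCCCCC(=O)NO` gives 15500 nM and compound 2 `Cc1cccc(Cc2cn(CCCCCC(=O)NO)c3ccc(-c4c(C)noc4C)cc23)c1` gives 15500 nM, so the two stand level. Compound 3 `Cc1noc(C)c1-c1ccc2c(c1)c(Cc1cccc(C(F)(F)F)c1)cn2CCCCCC(=O)NO` carries trifluoromethyl in place of methyl on an aromatic carbon, meta to a large group: trifluoromethyl in place of methyl on an aromatic carbon. Going by the values given here, only one measured step bears on this change, the methyl in place of hydrogen on an aromatic carbon, and it shows no change at the digits printed from compound 1 to compound 2 (within the scatter). One step is thin evidence, but it gives no ground for expecting a move beyond the scatter. The expected result is a 1.0-fold lower number from compound 2 to compound 3 (0.01 log units; within the scatter). Compound 3 is estimated at 15000 nM, with an expected range of 7000 nM to 32000 nM.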

Compound 3, concentration for 50% growth inhibition: 15500 nM
For compound 3 the middle estimate is 1.0-fold (0.01 log units) below the measured one; the range from low to high includes it.
By their numbers in this assay, from the lowest: compounds 1, 2 and 3 (each within the scatter of the next).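

In this assay trifluoromethyl in place of methyl shows no change at the digits printed from compound 2 to compound 3 (within the scatter) and trifluoromethyl in place of hydrogen shows no change at the digits printed from compound 1 to compound 3 (within the scatter) at this position. The methyl step alone could not say whether a group of more heavy atoms would register here; with trifluoromethyl the three compounds still do not separate. Nothing on hand offers an explanation for this flat read-out. On these data alone, whether an amine or a carboxylic acid at this position would separate from these three remains open, and so does whether any substituent here can move this read-out.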